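Replacing One Ring Group in Compound 2

A few compounds are considered here, and "the series" means these few. Any claim that something is new, unique, unknown or untested is made for them only; others in the source may bear on it.

Compound 1 `CC1CCN(C2CCN(S(=O)(=O)c3cccc(C(F)(F)F)c3)CC2)CC1` gives > 5000 nM (a limit)
Compound 2 `Cc1cc(C)c(S(=O)(=O)N2CCC(N3CCC(C)CC3)CC2)c(C)c1` gives > 5000 nM (a limit)
Compound 3 `CCc1cc(Br)ccc1S(=O)(=O)N1CCC(N2CCC(C)CC2)CC1` gives > 5000 nM (a limit)

In an ADME assay on HCT-116 cells (Homo sapiens) for cytotoxicity, read by CellTiter-Glo, with a stated time of 72 h (a higher number here means a weaker inhibitor, a lower number a stronger inhibitor), compound 2 gives > 5000 nM, which is a limit of the assay and not a number. Compound 2 has no exact place in a ranking, and the same holds for its two companions: the limit of > 5000 nM in this assay, at which 3 of the 3 values shown sit. With no exact values, nothing can be said about order among the three.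

Compound 4 `Cc1cc(C)c(S(=O)(=O)N2CCC(c3ccccc3)CC2)c(C)c1` is made from compound 2 by one change: phenyl in place of 4-methylpiperidin-1-yl on a saturated ring carbon. All three measured compounds carry 4-methylpiperidin-1-yl, so none of them shows directly what phenyl does.

For the measured compounds named here, no step between measured compounds is available as a guide. The expectation therefore rests on compound 2 and its limit of > 5000 nM, and no step beyond the usual scatter is expected in this assay. The estimated step is a step that the limit leaves unreadable from compound 2 to compound 4, and compound 4 will most likely be reported only as a limit again. Compound 4 is expected to give about 7000 nM, with an estimated range from 2500 nM to 20000 nM.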

Compound 4, half-maximal inhibitory concentration: > 5000 nM
Compound 4: no number, only a limit (the forecaster's own chance of this, stated with the estimate: 85%); the middle value lies beyond the limit too.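

In this assay compound 4 gives > 5000 nM, which is a limit and not a number. Compound 2 also sits at a limit, so no step can be read between compound 2 and compound 4: the limit of > 5000 nM in this assay, at which 4 of the 4 values shown sit.

The compounds shown leave open whether phenyl or 4-methylpiperidin-1-yl gives the stronger inhibitor in this assay.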